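The source may report more compounds than this note shows. Statements on the series, on what has been measured and on what is new or still open speak of the compounds shown alone.

Compound 1 `O=C1C2=C(CCCC2)C(=O)N1c1ccc(Cl)cc1F` is the simplest member of this small set; in a functional assay on the whole organism for inhibition, with Scenedesmus acutus as the target (on this read-out higher numbers stand for weaker inhibition and lower numbers for stronger inhibition), compound 1 gives 37.2 nM. Compound 3 `CC(C)COC(=O)c1cc(N2C(=O)C3=C(CCCC3)C2=O)c(F)cc1Cl` carries an isobutoxycarbonyl group and a fluoro group, and in this assay compound 3 gives 100 nM. Compound 2 `COC(=O)c1cc(N2C(=O)C3=C(CCCC3)C2=O)ccc1Cl` bears a methoxycarbonyl group and no fluoro group; in this assay compound 2 gives 1780 nM, the highest number of the three, which here means the weakest inhibition of the three. The new compound 4 `C#CCOc1cc(N2C(=O)C3=C(CCCC3)C2=O)ccc1Cl` arises from compound 2 by the change (propargyloxy in place of methoxycarbonyl on an aromatic carbon). Within the data shown here, only one measured step touches this part of the molecule: a 2.7-fold higher number from compound 1 to compound 3 (0.43 log units; beyond the scatter), showing that adding isobutoxycarbonyl cost a modest amount of potency. Among the measured compounds shown here, no measured pair shows what propargyloxy does, so any expectation here is loose. Compound 1, with hydrogen at this carbon, gives 37.2 nM, whereas compound 2 gives 1780 nM, so taking the methoxycarbonyl away is expected to lower the number. For compound 4 the expected step is a 12-fold lower number from compound 2 to compound 4 (1.07 log units; beyond the scatter). Compound 4 is therefore estimated at 150 nM, most likely between 30 nM and 800 nM.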

Compound 4, half-maximal inhibitory concentration: 100 nM
For compound 4 the middle estimate is 1.5-fold (0.18 log units) above the measured one; the range from low to high includes it.
By their numbers in this assay, from the lowest: compound 1; then compounds 3 and 4 (each within the scatter of the next); then compound 2.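

In this assay, putting propargyloxy in place of methoxycarbonyl gives an 18-fold lower number from compound 2 to compound 4 (1.25 log units; beyond the scatter), a large move towards stronger inhibition at this carbon, ortho to a chloro group. The earlier compounds shown here showed only a modest step, where isobutoxycarbonyl replaced hydrogen, whereas this pair shows that exchanging one group for another of the same heavy-atom count can change the read-out far more, with a triple bond entering, a double bond leaving and one hydrogen-bond acceptor fewer in the entering group. Nothing measured here explains why this exchange has so large an effect.

The compounds shown leave open which part of propargyloxy matters, the oxygen attached to the aromatic carbon or the triple bond, a question that a methoxy group or a saturated propoxy chain at this carbon would help to answer. Also open, from the compounds shown here alone, are how an amine or a carboxylic acid would read at this carbon, and whether propargyloxy would behave the same way alongside the fluoro group found in compound 1 and compound 3.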